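A few compounds are considered here, and "the series" means these few. Any claim that something is new, unique, unknown or untested is made for them only; others in the source may bear on it.

Series notes. Compound 1 `COc1cnc(O[C@@H]2C[C@H]3C(=O)N[C@]4(C(=O)NS(=O)(=O)C5CC5)C[C@H]4/C=C\CCCC[C@@H](C)[C@H](NC(=O)OC(C)(C)C)C(=O)N3C2)c2cc(Cl)ccc12` and compound 2 `COc1cnc(O[C@@H]2C[C@H]3C(=O)N[C@]4(C(=O)NS(=O)(=O)C5CC5)C[C@H]4/C=C\CCCC[C@@H](C)[C@H](NC(=O)OC(C)(C)C(F)(F)F)C(=O)N3C2)c2cc(Cl)ccc12` share one core; compound 3 `CC[C@@H]1C[C@H](C)CC/C=C\[C@@H]2C[C@@]2(C(=O)NS(=O)(=O)C2CC2)NC(=O)[C@@H]2C[C@@H](Oc3ncc(OC)c4ccccc34)CN2C(=O)[C@H]1NC(=O)OC(C)(C)C` and compound 4 `CC[C@@H]1C[C@H](C)CC/C=C\[C@@H]2C[C@@]2(C(=O)NS(=O)(=O)C2CC2)NC(=O)[C@@H]2C[C@@H](Oc3ncc(OC)c4ccccc34)CN2C(=O)[C@H]1NC(=O)OC(C)(C)C(F)(F)F` share another, and the difference between the two cores is not broken down here. In an ADME assay on microsomes from liver (Homo sapiens) for metabolic stability, read by LC-MS, using NADPH, with a stated time of 45 min (on this read-out higher numbers stand for a longer-lived compound and lower numbers for a shorter-lived compound), compound 1 gives 0.192 h and compound 2 gives 0.505 h. The change between them is trifluoromethyl in place of methyl on a saturated chain carbon bound to an oxygen next to a carbonyl group and two saturated chain carbons, and it made a step of a 2.6-fold higher number from compound 1 to compound 2 (0.42 log units; beyond the scatter). In this assay compound 3 gives 0.143 h; set against compound 1 this lies within the scatter, set against compound 2 beyond it. Compound 4 carries the same change on the core of compound 3, namely (trifluoromethyl in place of methyl on a saturated chain carbon bound to an oxygen next to a carbonyl group and two saturated chain carbons), at the same place as in the first pair. The step to compound 4 is expected to be about as large as the earlier one, because a 2.6-fold higher number from compound 1 to compound 2 (0.42 log units; beyond the scatter) is modest but beyond the scatter and nothing measured speaks against its carrying over to the second core. For compound 4 a step of a 2.3-fold higher number from compound 3 to compound 4 (0.36 log units; beyond the scatter) is therefore expected. The estimate for compound 4 in this assay is 0.33 h, between 0.16 h and 0.7 h.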

Compound 4, half-life: 0.628 h
Compound 4: middle estimate off by 1.9-fold (0.28 log units), on the low side; low and high end bracket the measured number.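

In this assay trifluoromethyl in place of methyl on a saturated chain carbon bound to an oxygen next to a carbonyl group and two saturated chain carbons gives a 4.4-fold higher number from compound 3 to compound 4 (0.64 log units; beyond the scatter) and so repeats on the core of compound 3 the direction seen on the core of compound 1. This supports carrying the change between these two cores for this read-out only; it does not show that either core responds more strongly, and it does not explain why the half-life rises. The two steps point the same way and their sizes cannot be told apart: the same change on two cores in this assay, a 2.6-fold higher number (0.42 log units; beyond the scatter) from compound 1 to compound 2 and a 4.4-fold higher number (0.64 log units; beyond the scatter) from compound 3 to compound 4, 1.7-fold (0.22 log units) apart, within the scatter of two such steps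

Open, as far as these compounds go, is whether difluoromethyl or a cyclobutyl group at the same place would give a step of similar size. Also open, from the compounds shown here alone, is whether the change carries over to any core other than these two, and which part of the difference between the two cores matters for the half-life.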